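A Triazole Nitrogen Swap: Benzyl Out, Aryl In

A few compounds are considered here, and "the series" means these few. Any claim that something is new, unique, unknown or untested is made for them only; others in the source may bear on it.

Compound 2 `COc1ccc(Cn2c(CCc3c[nH]c4ccccc34)nnc2[C@H](NC(=O)c2ccccn2)c2c[nH]c3ccccc23)c(OC)c1` is the stronger of the two measured compounds: in an in vitro assay on LLC-PK1 cells for displacement of a labelled ligand from growth hormone secretagogue receptor type 1 (Homo sapiens) (a higher number here means a weaker inhibitor, a lower number a stronger inhibitor), compound 2 gives 1.8 nM. Compound 1 `COc1ccc(Cn2c(CCc3c[nH]c4ccccc34)nnc2[C@H](NC(=O)C(C)(C)N)c2c[nH]c3ccccc23)c(OC)c1` gives 108 nM in this assay; the step of a 60-fold lower number from compound 1 to compound 2 (1.78 log units; beyond the scatter) exchanges only the group on the amide carbonyl, pyridin-2-yl in place of 1-amino-1-methylethyl, and leaves the rest untouched.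

Compound 3 `CCc1ccc(-n2c(CCc3c[nH]c4ccccc34)nnc2[C@H](NC(=O)c2ccccn2)c2c[nH]c3ccccc23)cc1` keeps the pyridin-2-yl amide of compound 2 and changes a different part of the shared core: 4-ethylphenyl in place of 2,4-dimethoxybenzyl on an aromatic nitrogen. The aromatic nitrogen of the five-membered ring now carries an aryl ring directly, with no linking methylene, and both methoxy groups are gone.

Going by the values given here, no measured step concerns this nitrogen substituent, so the single step from compound 1 to compound 2 says nothing about its size or direction. Among the compounds with values here, the expectation for compound 3 therefore rests on no comparable pair and is a guess that some potency may be lost: an estimated step of a 6.7-fold higher number from compound 2 to compound 3 (0.82 log units; beyond the scatter). Compound 3 is expected to give about 12 nM in this assay, within a range of 1.5 nM to 100 nM.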

Compound 3, half-maximal inhibitory concentration: 49 nM
For compound 3 the middle estimate is 4.1-fold (0.61 log units) below the measured one; measured number inside the range.
By their numbers in this assay, from the lowest: compound 2; then compound 3; then compound 1.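

The nitrogen substituent on the five-membered ring strongly affects the result in this assay: a 27-fold higher number from compound 2 to compound 3 (1.43 log units; beyond the scatter) when 4-ethylphenyl replaces 2,4-dimethoxybenzyl, so the group on the amide carbonyl is not the only part of these molecules that can shift the number by a large step. This single exchange alters several features at once: the linking methylene and both methoxy groups leave, an ethyl group enters, the substituent goes from 11 heavy atoms to 8, and its hydrogen-bond acceptors go from 2 to 0, so the step cannot be assigned to any one of these features. Nothing measured here explains why the number rises.

The compounds shown leave open whether the weaker binding follows from the aryl ring sitting directly on the nitrogen or from the missing methoxy groups, a question that 4-ethylbenzyl and 2,4-dimethoxyphenyl on this nitrogen could help separate. As far as these compounds go, it also remains open whether 4-ethylphenyl would produce a step of similar size alongside the 1-amino-1-methylethyl amide of compound 1.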